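Enone series: benzoate ester and cyclohexyl-to-chlorophenyl change

The source may hold more compounds than are shown below. What is called first, only, known or untested is meant among the compounds shown, and "the series" means these compounds.

Compound 1 `COc1ccc(C(=O)/C(=C/C2CCCCC2)COC(C)=O)cc1` is the acetate of the series. In a functional assay on A549 cells (Homo sapiens) for inhibition, read by XTT assay, with a stated time of 48 h (a lower number here means a stronger inhibitor, a higher number a weaker inhibitor), compound 1 gives 90000 nM. Compound 2 `COc1ccc(C(=O)/C(=C/C2CCCCC2)COC(=O)c2ccccc2)cc1` carries a benzoate in place of the acetate, and in this assay compound 2 gives 36000 nM. Within the data shown here, the step of a 2.5-fold lower number from compound 1 to compound 2 (0.40 log units; beyond the scatter) is the only measured step so far. Compound 2 therefore stands with the lowest of the two numbers, its nearest neighbour being compound 1.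

Compound 3 `COc1ccc(C(=O)/C(=C/c2ccccc2Cl)COC(=O)c2ccccc2)cc1` keeps the benzoate of compound 2 and differs at the other end of the chain: 2-chlorophenyl in place of cyclohexyl on a double-bonded chain carbon bound to a double-bonded chain carbon. Among the measured compounds shown here, no measured step touches this position; the single step from compound 1 to compound 2 concerns the acyl group alone and gives no direct precedent for the change here. The expectation for this assay therefore rests on the position of compound 2 with a wide allowance either way, and the step of a 1.2-fold lower number from compound 2 to compound 3 (0.08 log units; within the scatter) is estimated to stay close to the scatter. For compound 3 the value in this assay is expected near 30000 nM, within a range of 8000 nM to 100000 nM.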

Compound 3, half-maximal inhibitory concentration: 20100 nM
The estimate for compound 3 lay 1.5-fold (0.17 log units) above the measured number, within the range that was stated.
By their numbers in this assay, from the lowest: compounds 3 and 2 (each within the scatter of the next); then compound 1.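

Among these compounds, on a double-bonded chain carbon bound to a double-bonded chain carbon, the exchange of cyclohexyl for 2-chlorophenyl gives a 1.8-fold lower number from compound 2 to compound 3 (0.25 log units; within the scatter) in this assay, the first reading at this position. Among the compounds shown here, a six-membered aromatic ring of carbon bearing chlorine can therefore stand where the non-aromatic ring stood without a difference beyond the scatter, while the earlier acyl change, a 2.5-fold lower number from compound 1 to compound 2 (0.40 log units; beyond the scatter), remains the only step printed as beyond it. No measurement is available that accounts for either step.

The pair changes the ring type and adds chlorine in a single step, so the contribution of each cannot be separated without unsubstituted phenyl or with 3-chlorophenyl and 4-chlorophenyl at the same place. Also open, from the compounds shown here alone, are whether the reading at this position holds with the acetate in place of the benzoate, and how an amine, a carboxylic acid or a longer alkyl chain would read there in this assay on the core of compound 3.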